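The source may report more compounds than this note shows. Statements on the series, on what has been measured and on what is new or still open speak of the compounds shown alone.

Notes on the series. The shared core of compound 1 `CC(CCNC(=O)c1c(Cl)cncc1Cl)N1CCC(C(Oc2ncccc2Cl)c2ccc(C(F)(F)F)cc2)CC1` carries a dichloropyridine amide, a branched chain on the piperidine nitrogen and an aryl ether on the piperidine. In an ADME assay on PBMC cells (Homo sapiens) for cytotoxicity (a higher number here means that more compound is tolerated, a lower number that less compound is tolerated), compound 1 gives 16700 nM, the lowest of the two numbers recorded. Compound 2 `CCO/N=C(/c1ccc(Br)cc1)C1CCN(C(C)CCNC(=O)c2c(Cl)cncc2Cl)CC1`, an oxime ether rather than an aryl ether, gives 33800 nM in this assay, a higher number that lies beyond the scatter. Compound 3 `CC(CCNC(=O)c1c(Cl)cncc1Cl)N1CCC(C(Oc2cccc(Cl)n2)c2ccc(S(C)(=O)=O)cc2)CC1`, with a methylsulfonyl group in place of the trifluoromethyl group, is reported only as a limit of this assay, > 29500 nM, and the limit of > 29500 nM in this assay, at which 1 of the 3 values shown sits, is the only such limit among the three values.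

Compound 4 `CC(CCNC(=O)c1c(Cl)cncc1Cl)N1CCC(C(Oc2cc(Cl)ccn2)c2ccc(C(F)(F)F)cc2)CC1` has the same atoms as compound 1, joined differently: 4-chloropyridin-2-yl in place of 3-chloropyridin-2-yl on an oxygen on a saturated carbon. For the measured compounds named here, no measured pair in this assay differs in just this way, so the size of the step has to be judged from the change alone. The chloropyridinyl ether is kept, and only the position of the chlorine on that ring moves; the expected step from compound 1 to compound 4 in this assay is a 1.2-fold higher number from compound 1 to compound 4 (0.08 log units; within the scatter), meaning no change beyond the scatter. Compound 4 is thus estimated at 20000 nM in this assay, with a range from 8000 nM to 45000 nM.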

Compound 4, half-maximal cytotoxic concentration: 4260 nM
Compound 4: middle estimate off by 4.7-fold (0.67 log units), on the high side, and the stated range ends above it.
By their numbers in this assay, from the lowest: compound 4; then compound 1; then compound 2.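

In this assay, exchanging 3-chloropyridin-2-yl for 4-chloropyridin-2-yl on an oxygen on a saturated carbon gives a 3.9-fold lower number from compound 1 to compound 4 (0.59 log units; beyond the scatter) and so shows that this ether ring is sensitive to where its chlorine sits, even though the heavy atoms, donors and acceptors counted for the two groups are identical. For the compounds shown here, the earlier compounds differ from one another in more than one place, so this pair is the first direct reading at this position, and it rests on a single change of one isomer for another. Nothing measured here bears on the reason for this step.

The compounds shown leave open how an unsubstituted pyridin-2-yl, or a 4-methoxypyridin-2-yl or 4-cyanopyridin-2-yl group on the same oxygen, would read in this assay, and so whether the chlorine itself matters or only its place on the ring. Compound 3, which carries methylsulfonyl, is held only as a limit, > 29500 nM, so whether the same chlorine move would have a similar effect alongside that group also remains unanswered.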